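The source may report more compounds than this note shows. Statements on the series, on what has been measured and on what is new or still open speak of the compounds shown alone.

Measured in an ADME assay on Vero cells (Chlorocebus sabaeus) for cytotoxicity, read by reporter gene assay, with a stated time of 4 days; on this read-out lower numbers stand for stronger inhibition and higher numbers for weaker inhibition:
- compound 1 `CCCCCC(=O)NCC(C)(C)CC1=C(O)C(=O)c2ccccc2C1=O`: 46600 nM
- compound 2 `CCCC(C)C(=O)OCC(C)(C)CC1=C(O)C(=O)c2ccccc2C1=O`: 120 nM

Of the two measured compounds, compound 2 has the lower number, at 120 nM. Next comes compound 3 `CCCCCC(=O)OCC(C)(C)CC1=C(O)C(=O)c2ccccc2C1=O`, where pentyl takes the place of 1-methylbutyl on a carbonyl carbon: pentyl in place of 1-methylbutyl on a carbonyl carbon.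

Going by the values given here, only one measured step bears on this change: a 390-fold lower number from compound 1 to compound 2 (2.59 log units; beyond the scatter). That large step replaces (pentylcarbonyl)amino with ((1-methylbutyl)carbonyl)oxy, so it alters the link and the chain together. Among the compounds with values here, it cannot show how much the chain alone contributes, and no measured pair isolates that swap. Compound 3 keeps the (pentylcarbonyl)oxy form of the link, so it is expected to stay close to compound 2 at 120 nM rather than move towards compound 1. An estimated 1.3-fold higher number from compound 2 to compound 3 (0.10 log units; within the scatter) is expected in this assay, which would be no shift beyond the scatter. For compound 3 the expected value is 150 nM, with an estimated range of 40 nM to 800 nM.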

Compound 3, half-maximal inhibitory concentration: 169000 nM
The estimate for compound 3 lay 1100-fold (3.05 log units) below the measured number; the measured number lies above the stated range.
By their numbers in this assay, from the lowest: compound 2; then compound 1; then compound 3.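

In this assay, the link does not by itself account for the low number of compound 2: with the oxy link held, the change from 1-methylbutyl to pentyl on the carbonyl carbon gives a 1400-fold higher number from compound 2 to compound 3 (3.15 log units; beyond the scatter) in this series. With the pentyl chain held, the change of link gives only a 3.6-fold higher number from compound 1 to compound 3 (0.56 log units; beyond the scatter) and runs the opposite way to a 390-fold lower number from compound 1 to compound 2 (2.59 log units; beyond the scatter), so the chain change tracks most of that earlier large step. Nothing available explains why these two chains of equal heavy-atom count read so differently.

Going by these compounds alone, compound 2 is the only low number here, so it remains open whether any branched chain on this carbonyl carbon gives the same result. The 1-methylbutyl group on the amide link, and shorter or differently branched groups such as 1-methylethyl or 1,1-dimethylethyl on the ester, would test this.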